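Shifting the chlorine on the chlorophenyl group of compound 3

The compounds below may be only part of what the source reports. "The series", "measured", "known", "first", "only" and "open" are said of these compounds alone.

Compound 3 `C=CC(=O)Nc1cccc(NC(=O)CSc2nc(Nc3ccccc3Cl)c3ccccc3n2)c1` gives 10000 nM in a functional assay on NCI-H1975 cells (Homo sapiens) for inhibition, read by MTT assay, with a stated time of 72 h (a higher number here means a weaker inhibitor, a lower number a stronger inhibitor), the smallest of the three numbers shown, yet its gaps to compound 1 `O=C(CSc1nc(Nc2ccccc2)c2ccccc2n1)Nc1cccc(Br)c1`, which gives 10100 nM, and to compound 2 `O=C(CSc1nc(Nc2ccccc2)c2ccccc2n1)Nc1ccc([N+](=O)[O-])cc1`, which gives 13000 nM, both lie within the scatter. Compound 4 `C=CC(=O)Nc1cccc(NC(=O)CSc2nc(Nc3cccc(Cl)c3)c3ccccc3n2)c1` differs from compound 3 by 3-chlorophenyl in place of 2-chlorophenyl on a nitrogen on an aromatic ring. Within the data shown here, the only measured step, a 1.3-fold higher number from compound 1 to compound 2 (0.11 log units; within the scatter), concerns the amide-type nitrogen, not this position, and stayed within the scatter, so it offers no direct guide. Among the measured compounds shown here, no measured pair touches the chlorine's placement. With all three numbers so close, no step beyond the scatter is expected, and the expected step is no change at the digits printed from compound 3 to compound 4 (within the scatter). Compound 4 is therefore estimated at 10000 nM, with a range from 4000 nM to 25000 nM.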

Compound 4, half-maximal inhibitory concentration: 9460 nM
Beside the measured number, compound 4's estimate is 1.1-fold (0.02 log units) above it; measured number inside the range.
By their numbers in this assay, from the lowest: compounds 4, 3, 1 and 2 (each within the scatter of the next).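

In this assay, 3-chlorophenyl in place of 2-chlorophenyl on a nitrogen on an aromatic ring gives a 1.1-fold lower number from compound 3 to compound 4 (0.02 log units; within the scatter). Among these compounds, this is the first direct test of where the chlorine sits, and between these two placements it shows no readable difference. Nothing shown explains this result. On these data alone, it remains open whether an amine or a methoxy group in place of the chlorine, with the rest of compound 4 unchanged, would shift the number beyond the scatter. As far as these compounds go, a plain phenyl there is equally open.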